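Removing the Trifluoromethyl from a Weakly Active Amide

The source may report more compounds than this note shows. Statements on the series, on what has been measured and on what is new or still open speak of the compounds shown alone.

Compound 1 `COc1cc(-c2nn(-c3cccc(NC(=O)c4cccc(C(F)(F)F)c4)c3)cc2-c2ccncc2)ccc1Cl`: > 50000 nM
Compound 2 `O=C(Nc1cccc(-n2cc(-c3ccncc3)c(-c3ccc(Cl)c(O)c3)n2)c1)Nc1cc(C(F)(F)F)cc(C(F)(F)F)c1`: 4080 nM

In a functional assay on Hs-578T cells (Homo sapiens) for inhibition, read by sulforhodamine B assay, with a stated time of 48 h (on this read-out higher numbers stand for weaker inhibition of growth and lower numbers for stronger inhibition of growth), compound 1 is recorded only as a limit, > 50000 nM, not as a number. Compound 2 gives 4080 nM in this assay. With only the limit of > 50000 nM in this assay, at which 1 of the 2 values shown sits, known for compound 1, its standing is a floor rather than a value. Compound 3 `COc1cc(-c2nn(-c3cccc(NC(=O)c4ccccc4)c3)cc2-c2ccncc2)ccc1Cl` differs from compound 1 by hydrogen in place of trifluoromethyl on an aromatic carbon. Among the compounds with values here, no measured pair isolates this change, so a step of no more than the usual scatter, in either direction, is expected: a step that the limit leaves unreadable from compound 1 to compound 3. Compound 3 is therefore expected at 60000 nM, between 20000 nM and 200000 nM, most likely again reported only as a limit.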

Compound 3, concentration for total growth inhibition: > 100000 nM
Compound 3: a limit, no number; the forecaster's own chance of this, stated with the estimate: 70%; middle value at least 1.6-fold (0.22 log units) from the limit.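

In this assay compound 3 is recorded only as a limit, > 100000 nM. Compound 1 is also only a limit, so no step can be read between compound 1 and compound 3. As far as these compounds go, whether hydrogen in place of trifluoromethyl changes growth inhibition at all remains open.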